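The source may hold more compounds than are shown below. What is called first, only, known or untested is meant among the compounds shown, and "the series" means these compounds.

Three compounds share one core and differ in the group on the phenyl ring attached to it. Compound 1 `COc1ccc(C2=Nn3c(nnc3C(C)c3ccc(-c4ccccc4)c(F)c3)SC2)cc1` carries a methoxy group there, compound 2 `CC(c1ccc(-c2ccccc2)c(F)c1)c1nnc2n1N=C(c1ccc(Br)cc1)CS2` a bromo group, and compound 3 `CC(C)Cc1ccc(C(C)c2nnc3n2N=C(c2ccc(Br)cc2)CS3)cc1`, which also has an isobutyl group in place of the fluorobiphenyl on the other side, a bromo group as well. In a functional assay on FOCUS cells (Homo sapiens) for inhibition, read by sulforhodamine B assay, with a stated time of 72 h (on this read-out higher numbers stand for weaker inhibition and lower numbers for stronger inhibition), compound 1 gives 4400 nM, compound 2 gives 8500 nM, and compound 3 gives 5900 nM. Compound 2 thus gives the highest number of the three, though its gaps to compound 3 and to compound 1 both lie within the scatter.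

Among the compounds with values here, the one step that bears on the change to come, a 1.9-fold higher number from compound 1 to compound 2 (0.29 log units; within the scatter), is within the scatter. Compound 4 `CC(c1ccc(-c2ccccc2)c(F)c1)c1nnc2n1N=C(c1ccc([N+](=O)[O-])cc1)CS2` is the next compound, made from compound 2 by nitro in place of bromo on an aromatic carbon. Within the data shown here, no measured pair swaps bromo for nitro, so the expectation rests only on the methoxy-to-bromo swap, which moved the number little. The expected step of a 1.1-fold lower number from compound 2 to compound 4 (0.03 log units; within the scatter) from compound 2 to compound 4 is therefore none beyond the scatter. In this assay compound 4 is estimated at 8000 nM, with a range from 3000 nM to 20000 nM.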

Compound 4, half-maximal inhibitory concentration: 3500 nM
Beside the measured number, compound 4's estimate is 2.3-fold (0.36 log units) above it, within the range that was stated.
By their numbers in this assay, from the lowest: compounds 4, 1, 3 and 2 (each within the scatter of the next, the first and the last beyond it).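

In this assay there is a 2.4-fold lower number from compound 2 to compound 4 (0.39 log units; beyond the scatter) on the swap of 4-bromophenyl to 4-nitrophenyl, which shows that the group at this place, para to a large group, can shift the number by a modest step beyond the scatter, something the methoxy-to-bromo swap had not shown. The same assay gives a 1.3-fold lower number from compound 1 to compound 4 (0.10 log units; within the scatter) for the swap of methoxy to nitro, so these two groups cannot be told apart here, and bromo and methoxy also lie within the scatter of each other, which leaves only the bromo-to-nitro pair separated, and only modestly. The data shown offer no measurement that could explain why nitro and bromo differ at this place.

The compounds shown leave open how an amine, a carboxylic acid or a nitrile at this place would compare with nitro, and so whether the step seen here extends to other groups. They also leave open whether the nitro group gives a similar step when the isobutyl group of compound 3 replaces the fluorobiphenyl on the other side of the core.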